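Methylating the Phenol of Compound 3

The source may report more compounds than this note shows. Statements on the series, on what has been measured and on what is new or still open speak of the compounds shown alone.

Three compounds of the shared core have numbers in a functional assay on A549 cells (Homo sapiens) for inhibition, read by sulforhodamine B assay, with a stated time of 48 h, tested at 10 uM; on this read-out higher numbers stand for a weaker effect at the one concentration tested and lower numbers for a stronger effect. Compound 1 `COc1cc(Cl)cc(-c2nn(-c3cccc(NC(=O)Nc4cccc(C(F)(F)F)c4)c3)cc2-c2ccncc2)c1` gives 8.08%. Going by the values given here, compound 2 `COc1cc(Cl)cc(-c2nn(-c3cccc(NC(=O)c4cccc(C(F)(F)F)c4)c3)cc2-c2ccncc2)c1` gives 39.1%; the one measured step, a number 31 percentage points higher from compound 1 to compound 2 (beyond the scatter), comes from a 3-(trifluoromethyl)phenyl in place of (3-(trifluoromethyl)phenyl)amino on a carbonyl carbon. Compound 3 `O=C(Nc1cccc(-n2cc(-c3ccncc3)c(-c3cc(O)cc(Cl)c3)n2)c1)c1cc(C(F)(F)F)cc(C(F)(F)F)c1` gives 27.3%, which places it second highest of the three, nearer to compound 2 than to compound 1, and beyond the scatter from each of them.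

Compound 4 `COc1cc(Cl)cc(-c2nn(-c3cccc(NC(=O)c4cc(C(F)(F)F)cc(C(F)(F)F)c4)c3)cc2-c2ccncc2)c1` differs from compound 3 by methyl in place of hydrogen on an oxygen on an aromatic ring. Among the compounds with values here, no measured pair shows this change: compounds 1 and 2 carry the methoxy group, but each also carries a different group on the carbonyl carbon than compound 3, so their values cannot be split between the two differences. Within the data shown here, the one known step, from compound 1 to compound 2, concerns the carbonyl carbon and says nothing about an oxygen on an aromatic ring. With no guide, a step of a number 2.7 percentage points higher from compound 3 to compound 4 (within the scatter) in this assay is expected, that is none beyond the scatter. Compound 4 is therefore estimated at 30%, in a range from 10% to 55%.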

Compound 4, a percentage reported as activity, at one concentration (the size of the read-out at that concentration, not a potency): 43.5%
Beside the measured number, compound 4's estimate is 13.5 percentage points below it; the range from low to high includes it.
By their numbers in this assay, from the lowest: compound 1; then compound 3; then compounds 2 and 4 (each within the scatter of the next).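

In this assay the hydroxy to methoxy change now has a measured pair: methyl in place of hydrogen on the oxygen gives a number 16.2 percentage points higher from compound 3 to compound 4 (beyond the scatter) and so a weaker effect at the one concentration tested, which shows that this oxygen's substituent alters the read-out when the rest of the molecule is held fixed. Trifluoromethyl in place of hydrogen on an aromatic carbon gives a number 4.4 percentage points higher from compound 2 to compound 4 (within the scatter) and so leaves no readable difference on the methoxy compounds. Nothing at hand explains why the methoxy compound differs from the hydroxy compound.

Going by these compounds, whether an ethoxy group or an amino group in place of the hydroxy would read like compound 3 or like compound 4 stays open. Also open, on these data alone, is whether the same step would appear with the (3-(trifluoromethyl)phenyl)amino group of compound 1 on the carbonyl carbon.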